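The source may report more compounds than this note shows. Statements on the series, on what has been measured and on what is new or still open speak of the compounds shown alone.

Measured so far in an ADME assay on microsomes from liver (Rattus norvegicus) for metabolic stability, read by LC-MS, using NADPH, with a stated time of 10 min, tested at 0.5 uM; a higher number here means that more of the compound is left, a lower number that less of the compound is left 
- compound 1 `COC(=O)Nc1cc(-c2ccc(OC[C@@](C)(N)CC(C)C)c(C)c2)ccn1` gives 96% 
- compound 2 `COC(=O)Nc1cc(-c2ccc(OC[C@@](C)(N)CC(C)C)c(F)c2)ccn1` gives 94% 

Only these two numbers are available, and the step of a number 2 percentage points lower from compound 1 to compound 2 (within the scatter) lies within the scatter. Going by the values given here, compound 1 therefore cannot be separated from its one neighbour, and both stand near the top of the percentage scale.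

Compound 3 `COC(=O)Nc1cc(-c2ccc(OC[C@@](C)(N)CC(C)C)c(C)c2C)ccn1` keeps the core of compound 1 and changes it in one place: methyl in place of hydrogen on an aromatic carbon. This puts methyl in place of hydrogen on an aromatic carbon, ortho to a large group and ortho to a methyl group.

Among the compounds with values here, one measured step bears on this change, and only indirectly. The step of a number 2 percentage points lower from compound 1 to compound 2 (within the scatter) is fluoro in place of methyl on an aromatic carbon, which is a different change at a different carbon, and it stayed within the scatter. Within the data shown here, no measurement yet shows a group on the carbon that changes in compound 3, so the expectation is uncertain.

No shift beyond the scatter is expected, and the estimated step is a number 3 percentage points lower from compound 1 to compound 3 (within the scatter), with a slight allowance for a loss. The expected value for compound 3 is 93%, within an estimated range from 82% to 99%.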

Compound 3, percent of the compound remaining: 83%
Estimate against measurement, compound 3: 10 percentage points above, and the stated range covers the measured number.
By their numbers in this assay, from the lowest: compound 3; then compounds 2 and 1 (each within the scatter of the next).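

In this assay, going by these compounds alone, the aromatic carbon ortho to a large group and ortho to a methyl group proves sensitive to substitution: methyl in place of hydrogen there gives a number 13 percentage points lower from compound 1 to compound 3 (beyond the scatter), the first step in this small set to pass beyond the scatter. Within the data shown here, the only earlier step, fluoro in place of methyl on a different aromatic carbon, gave a number 2 percentage points lower from compound 1 to compound 2 (within the scatter), so a one-carbon addition at this new position registers in the read-out where that exchange did not. Nothing available accounts for the lower number, which therefore stands as an observation without an explanation.

The compounds shown leave open whether this loss belongs to methyl in particular or would also follow from another group on the same carbon, such as fluoro, chloro or methoxy. They also leave open whether the step would keep its size if the neighbouring methyl group were exchanged for fluoro, or if the (2-amino-2,4-dimethylpentyl)oxy group gave way to a shorter chain.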